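This account rests on a few compounds, and the source may have more. Where it says the series, first, only, none or still open, it means among the compounds named here.

Compound 1 `CCC(C)(C)Cc1c[nH]c(CCc2ccc(-n3ncnn3)cc2)n1`: 25 nM in a functional assay on HEK293 cells for agonist activity at Bombesin receptor subtype-3 (Mus musculus), read by luminescence and calcium flux, with a stated time of 10 min; on this read-out higher numbers stand for an effect only at larger amounts of compound and lower numbers for an effect already at smaller amounts.
Compound 2 `O=C(O)c1cc(F)c(F)cc1-c1ccc(CCc2nc(CC3CCCCC3)c[nH]2)cc1`: 4.7 nM in this assay.

Of these two numbers compound 1 has the highest; compound 2 stands at a lower number, beyond the scatter. Compound 3 `CCC(C)(C)Cc1c[nH]c(CCc2ccc(-c3cccnc3C(=O)O)cc2)n1` differs from compound 1 in one place: 2-carboxypyridin-3-yl in place of 2H-tetrazol-2-yl on an aromatic carbon. Among the compounds with values here, no step between measured compounds carries this change, so the direction rests only on compound 2, which also bears an acid-substituted aromatic ring and gives 4.7 nM in this assay. A moderate step toward a lower number is therefore expected, a 2.8-fold lower number from compound 1 to compound 3 (0.44 log units; beyond the scatter). Compound 3 is estimated at 9 nM, with a range from 2.5 nM to 35 nM.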

Compound 3, half-maximal effective concentration: 14 nM
The estimate for compound 3 lay 1.6-fold (0.19 log units) below the measured number, within the range that was stated.
By their numbers in this assay, from the lowest: compound 2; then compounds 3 and 1 (each within the scatter of the next).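

In this assay, putting 2-carboxypyridin-3-yl in place of 2H-tetrazol-2-yl gives a 1.8-fold lower number from compound 1 to compound 3 (0.25 log units; within the scatter), so on this read-out the two groups cannot be told apart. This aromatic carbon, para to a large group, thus carries either a five-membered aromatic ring with 4 hetero atoms or a larger six-membered one bearing an acid, with no difference beyond the scatter. No measurement at hand offers an explanation for this. From the compounds shown here alone, what a primary amide or a methyl ester would do in place of the carboxylic acid stays open, as does the effect of a plain phenyl ring in place of the pyridine.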